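The source may hold more compounds than are shown below. What is called first, only, known or untested is meant among the compounds shown, and "the series" means these compounds.

Measured so far:
compound 1, `C=CCn1c(=O)/c(=C\c2ccccc2Cl)[nH]c(=O)/c1=C\c1ccccc1OC`: 4700 nM
compound 2, `COc1ccccc1/C=c1\c(=O)[nH]/c(=C/c2ccccc2Cl)c(=O)n1C`: 200 nM

In a functional assay on MCF7 cells (Homo sapiens) for cytotoxicity, read by CCK-8 assay, with a stated time of 72 h (on this read-out lower numbers stand for stronger inhibition and higher numbers for weaker inhibition), compound 1 stands with the highest of the two numbers; its nearest neighbour is compound 2, reached by a 24-fold lower number from compound 1 to compound 2 (1.37 log units; beyond the scatter) through hydrogen in place of vinyl on a saturated chain carbon bound to an aromatic nitrogen. Compound 3, `C=CCn1c(=O)/c(=C\c2ccccc2F)[nH]c(=O)/c1=C\c1ccccc1OC`, keeps the vinyl chain of compound 1 and differs from it only by fluoro in place of chloro on an aromatic carbon, that is, 2-chlorophenyl to 2-fluorophenyl. Among the compounds with values here, no measured step touches this place: the single step at hand, a 24-fold lower number from compound 1 to compound 2 (1.37 log units; beyond the scatter), concerns the chain on the aromatic nitrogen and was large, and it tells nothing about fluoro against chloro. With no guidance from the data, the expectation for compound 3 is a step of no size beyond the scatter in this assay in either direction. Compound 3 is thus expected to give 4700 nM, with a range from 1800 nM to 12000 nM. The expected step from compound 1 is no change at the digits printed from compound 1 to compound 3 (within the scatter).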

Compound 3, half-maximal inhibitory concentration: 23000 nM
Compound 3: middle estimate off by 4.9-fold (0.69 log units), on the low side, and the stated range ends below it.
By their numbers in this assay, from the lowest: compound 2; then compound 1; then compound 3.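

In this assay the halogen on the aromatic carbon proves to matter in its own right: with the vinyl chain kept, the change from 2-chlorophenyl to 2-fluorophenyl gives a 4.9-fold higher number from compound 1 to compound 3 (0.69 log units; beyond the scatter) as a modest step. The core of compound 1 thus has a second place where a single change moves the number, besides the chain on the aromatic nitrogen, and here chloro goes with the lower number of the pair. Nothing at hand accounts for this difference between the two halogens.

Open, from the compounds shown here alone, is whether the same exchange would move the number by a like amount with the chain of compound 2 in place of the vinyl chain. Also open, going by these compounds, is how bromo, or a plain hydrogen, would read at this aromatic carbon.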